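The source may hold more compounds than are shown below. What is called first, only, known or untested is meant among the compounds shown, and "the series" means these compounds.

Measured so far:
Compound 1 `C[C@]1(CO)OC[C@@H](n2ccc(N)nc2=O)O1` gives 100000 nM in a functional assay on B16-F10 cells (Mus musculus) for inhibition; on this read-out lower numbers stand for stronger inhibition and higher numbers for weaker inhibition.
Compound 2 `C[C@]1(CO)OC[C@@H](n2cc(F)c(N)nc2=O)O1` gives only a limit of the assay, > 100000 nM, in this assay.
Compound 3 `CC1(CO)OC[C@@H](n2ccc(N)nc2=O)O1` gives only a limit of the assay, > 100000 nM, in this assay.

Among the measured compounds shown here, compound 1 is the one compound of the three with a number rather than a limit. The step of a number no lower from compound 1 to compound 2 (the limit leaves the size open) follows the change (fluoro in place of hydrogen on an aromatic carbon); its size cannot be read, because the limit of > 100000 nM in this assay, at which 2 of the 3 values shown sit, leaves it open. As far as these compounds go, the step of a number no lower from compound 1 to compound 3 (the limit leaves the size open) follows the difference (the two compounds have the same atoms and bonds; at least one stereo element is drawn with a configuration in one of them and without one in the other: 1 of 2 stereo elements differ; a stereocentre at a saturated ring carbon is drawn S in compound 1 and without a configuration in compound 3), and here too the size stays open because the fact that one of compounds 1 and 3 is drawn with a defined configuration and the other without, at the place where they differ is the only thing that separates the two drawings. The cores of compound 3 and compound 1 differ in this way alone: the two compounds have the same atoms and bonds; at least one stereo element is drawn with a configuration in one of them and without one in the other: 1 of 2 stereo elements differ; a stereocentre at a saturated ring carbon is drawn S in compound 1 and without a configuration in compound 3.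

Compound 4 is `CC1(CO)OC[C@@H](n2cc(F)c(N)nc2=O)O1`, not yet measured. It differs from compound 3 by fluoro in place of hydrogen on an aromatic carbon. This is the same change that leads from compound 1 to compound 2, made at the same place in the same surroundings. Compound 3 already gives only a limit of the assay, > 100000 nM. For compound 4 the step is expected to be a step that the limit leaves unreadable from compound 3 to compound 4, resting on the step of a number no lower from compound 1 to compound 2 (the limit leaves the size open), which went no lower. Compound 4 is therefore expected to give about 200000 nM in this assay, most likely as a limit again, with a range estimated from 100000 nM to 1000000 nM.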

Compound 4, half-maximal inhibitory concentration: > 100000 nM
Compound 4: no number, only a limit; the forecaster's own chance of this, stated with the estimate: 90%; the middle value does not contradict the limit.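

In this assay compound 4 gives > 100000 nM, which is a limit of the assay and not a number. Among the compounds shown here, neither the step to compound 4 from compound 3 nor the one from compound 2 can be read, as each joins two limits. The compounds shown leave open how much, if at all, fluoro in place of hydrogen or the drawn configuration changes inhibition in this assay.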